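The source may hold more compounds than are shown below. What is called first, only, known or untested is meant among the compounds shown, and "the series" means these compounds.

Working notes on the series.

The shared core is seen in compound 1 `C=CCn1c(-c2cc(OC)c(OC)cc2C=O)cc2ccccc2c1=O` and compound 2 `COCOCc1cc(OC)c(OC)cc1-c1cc2ccccc2c(=O)[nH]1`, which differ at the substituent bearing the carbonyl and in what sits on the nitrogen of the core. In a functional assay on HCT-15 cells (Homo sapiens) for cytotoxicity, read by MTT assay, with a stated time of 48 h (on this read-out higher numbers stand for weaker inhibition and lower numbers for stronger inhibition), compound 1 gives 77500 nM. In this assay compound 2 gives 73700 nM. These two numbers lie within the usual scatter of each other, so the data so far do not set compound 2 apart from compound 1; both sit at the weak end of what this read-out can resolve.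

Compound 3 `COCOCc1cc(OC)ccc1-c1cc2ccccc2c(=O)[nH]1` is the next member. It differs from compound 2 in one place (hydrogen in place of methoxy on an aromatic carbon).

For the measured compounds named here, no step between measured compounds is available to calibrate this change, and the two known numbers give no trend to lean on. The working expectation is a step in this assay of no more than the scatter, perhaps a slight drift toward weaker inhibition, expressed as a 1.2-fold higher number from compound 2 to compound 3 (0.09 log units; within the scatter). Compound 3 is thus estimated at 90000 nM, with a range from 35000 nM to 250000 nM.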

Compound 3, half-maximal inhibitory concentration: 27500 nM
Compound 3: the middle estimate sits 3.3-fold (0.51 log units) above what was measured; measured number below the stated range.
By their numbers in this assay, from the lowest: compound 3; then compounds 2 and 1 (each within the scatter of the next).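

Hydrogen in place of methoxy on this aromatic carbon, ortho to a methoxy group and para to a (methoxymethoxy)methyl group, gives in this assay a 2.7-fold lower number from compound 2 to compound 3 (0.43 log units; beyond the scatter). For the compounds shown here, this is the first change in a single place to be read, and it shows that the position responds to substitution and that the methoxy lost here is not required for the activity seen on this read-out, although the step is modest and rests on one pair. Compounds 1 and 2 could not show this, since they differ in more than one place and their values lie within the scatter of each other, and no measurement at hand accounts for the step.

Still open, going by these compounds, is whether the response belongs to the absence of a group at this carbon or to the particular group present, which a fluorine, a chlorine, a hydroxyl or a longer ethoxy chain at the same carbon would help to separate. Also open, on these data alone, is whether replacing the remaining methoxy with hydrogen, or the same change made with the substituents of compound 1 in place, would produce a step of similar direction and size.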